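Nitrophenyl for chlorophenyl on the anilino arm

The source may report more compounds than this note shows. Statements on the series, on what has been measured and on what is new or still open speak of the compounds shown alone.

Measured so far:
compound 1, `O=C(CSc1nc(Nc2ccccc2)c2ccccc2n1)Nc1ccc([N+](=O)[O-])cc1`, > 50000 nM
compound 2, `C=CC(=O)Nc1cccc(NC(=O)CSc2nc(Nc3ccccc3Cl)c3ccccc3n2)c1`, 20700 nM

In a functional assay on MGC-803 cells (Homo sapiens) for inhibition, read by MTT assay, with a stated time of 72 h (a higher number here means a weaker inhibitor, a lower number a stronger inhibitor), compound 2 gives 20700 nM, the only actual number shown. For compound 1 the result is a limit of the assay, > 50000 nM, which is the limit of > 50000 nM in this assay, at which 1 of the 2 values shown sits. Compound 3, `C=CC(=O)Nc1cccc(NC(=O)CSc2nc(Nc3cccc([N+](=O)[O-])c3)c3ccccc3n2)c1`, is not yet measured and differs from compound 2 in one place: 3-nitrophenyl in place of 2-chlorophenyl on a nitrogen on an aromatic ring. No measured step of this kind is shown, so a step from compound 2 to compound 3 no larger than the usual scatter is expected, in either direction. Compound 3 is therefore estimated at 30000 nM, between 10000 nM and 100000 nM. This corresponds to an expected step of a 1.4-fold higher number from compound 2 to compound 3 (0.16 log units; within the scatter).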

Compound 3, half-maximal inhibitory concentration: > 50000 nM
Compound 3 gave a limit, no number (the forecaster's own chance of this, stated with the estimate: 35%); middle value at least 1.6-fold (0.22 log units) from the limit.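

On a nitrogen on an aromatic ring, 3-nitrophenyl in place of 2-chlorophenyl gives the first one-place comparison, and in this assay it produces an at least 2.4-fold higher number from compound 2 to compound 3 (0.38 log units; beyond the scatter). This position is therefore not indifferent to the group it carries, and this change weakens inhibition beyond the scatter. The result for compound 3 is a limit of the assay, not a number, so the full size of the loss cannot be read: the limit of > 50000 nM in this assay, at which 2 of the 3 values shown sit.

The compounds shown do not separate the effect of the nitro group from that of its place on the ring. A 3-chlorophenyl or 2-nitrophenyl group on the same nitrogen would tell these apart.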